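Working notes on the group at the ring nitrogen

The source may hold more compounds than are shown below. What is called first, only, known or untested is meant among the compounds shown, and "the series" means these compounds.

Measured so far in a functional assay (strain AB) with Danio rerio as the target, read by microscopy, with a stated time of 1 h (a lower number here means that less compound is needed, a higher number that more compound is needed for the effect), are three compounds
- compound 1 `C[N+]1(CC2CCC2)CCc2c(sc(NC(=O)Nc3ccc(Cl)cc3)c2C(N)=O)C1` gives 210 nM
- compound 2 `CCN1CCc2c(sc(NC(=O)Nc3ccc(Cl)cc3)c2C(N)=O)C1` gives 3120 nM
- compound 3 `NC(=O)c1c(NC(=O)Nc2ccc(Cl)cc2)sc2c1CCN(CC1CCCCC1)C2` gives 1890 nM

In this assay compound 3 at 1890 nM sits within the scatter of compound 2 at 3120 nM and compound 1 at 210 nM shows a clearly lower number than both.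

Still unmeasured is compound 4 `CC(C)(C)OC(=O)N1CCc2c(sc(NC(=O)Nc3ccc(Cl)cc3)c2C(N)=O)C1` which differs from compound 3 as follows tert-butoxycarbonyl in place of cyclohexylmethyl on an amine nitrogen in a ring and so tert-butoxycarbonyl stands in place of cyclohexylmethyl on an amine nitrogen in a ring.

For the measured compounds named here, the one measured step between two such compounds is a 1.7-fold lower number from compound 2 to compound 3 (0.22 log units; within the scatter) and it stays within the scatter. Compound 1 at 210 nM also differs from compound 3 only at that nitrogen, so the number can move with the group there. Going by the values given here, no measured compound carries tert-butoxycarbonyl, which leaves the expectation loose. With a 1.7-fold lower number from compound 2 to compound 3 (0.22 log units; within the scatter) as the closest guide, no step beyond the scatter is expected. The estimated step is a 1.3-fold higher number from compound 3 to compound 4 (0.12 log units; within the scatter) and it is expected to stay within the scatter. The estimate for compound 4 is 2500 nM in this assay with an expected range from 800 nM to 7500 nM around it.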

Compound 4, half-maximal effective concentration: > 25000 nM
Compound 4 ended at the assay's limit; the forecaster's own chance of this, stated with the estimate: 10%; middle value at least 10-fold (1.00 log units) from the limit.
By their numbers in this assay, from the lowest: compound 1; then compounds 3 and 2 (each within the scatter of the next). At a limit, above all of these: compound 4.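

In this assay, for the compounds shown here, the group on the amine nitrogen in a ring can also drive the number sharply upward, which the earlier compounds did not show: tert-butoxycarbonyl gives an at least 13-fold higher number from compound 3 to compound 4 (1.12 log units; beyond the scatter), and measured against ethyl it gives an at least 8.0-fold higher number from compound 2 to compound 4 (0.90 log units; beyond the scatter). Both steps lie beyond the scatter, whereas a 1.7-fold lower number from compound 2 to compound 3 (0.22 log units; within the scatter) does not, so the nitrogen tolerates ethyl and cyclohexylmethyl alike, while tert-butoxycarbonyl, with the same count of heavy atoms as cyclohexylmethyl, breaks that picture. The value of compound 4 is a limit and not a number, so the true size of both steps stays unknown: the limit of > 25000 nM in this assay, at which 1 of the 4 values shown sits.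

The compounds shown do not separate the carbonyl, the second oxygen and the absence of a ring, as compound 4 alone carries this combination of features. Acetyl, methoxycarbonyl or a plain tert-butyl group on that nitrogen would help to separate them, and cyclobutylmethyl on an uncharged nitrogen would test how much of the number of compound 1 at 210 nM goes with its extra methyl group and charge.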